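Piperidine in place of pyrrolidine on the aryl ether chain

The source may hold more compounds than are shown below. What is called first, only, known or untested is meant among the compounds shown, and "the series" means these compounds.

Three members of the series carry the same core with a butyl group and a chlorophenoxy-substituted aryl ring. Compound 1 `CCCCc1sc(-c2ccc(OCCCN3CCCC3)cc2)nc1-c1ccc(Oc2ccc(Cl)cc2)cc1` bears a basic chain on one aryl oxygen; in an assay on isolated protein for antagonist activity at advanced glycosylation end product-specific receptor (Homo sapiens), read by ELISA, with a stated time of 60 min, tested at 10 uM (on this read-out lower numbers stand for less inhibition and higher numbers for more inhibition at the one concentration tested (going by the name of the read-out)), compound 1 gives 47.8%, the lowest of the three numbers, though within the scatter of both others. Compound 2 `CCCCc1sc(-c2ccc(Oc3ccc(Cl)cc3)cc2)nc1-c1ccc(OCCCN(CC)CC)cc1`, with the basic chain on the other aryl ring, gives 57% in this assay. Compound 3 `CCCCc1sc(C(=O)Nc2ccc(OCCCN(CC)CC)cc2)nc1-c1ccc(Oc2ccc(Cl)cc2)cc1`, an amide-linked analogue, gives 48.1%. Compound 4 `CCCCc1sc(-c2ccc(OCC3CCCN(CC)C3)cc2)nc1-c1ccc(Oc2ccc(Cl)cc2)cc1` differs from compound 1 in one place: 1-ethylpiperidin-3-yl in place of 2-(pyrrolidin-1-yl)ethyl on a saturated chain carbon bound to an oxygen on an aromatic ring. Within the data shown here, no measured pair shows a step of this kind, so no movement beyond the scatter is expected from compound 1 to compound 4, a number 2.2 percentage points higher from compound 1 to compound 4 (within the scatter). Compound 4 is estimated at 50%, range 35% to 65%.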

Compound 4, a percentage reported as inhibition, at one concentration (the size of the read-out at that concentration, not a potency): 58%
The estimate for compound 4 lay 8 percentage points below the measured number; low and high end bracket the measured number.
By their numbers in this assay, from the lowest: compounds 1, 3, 2 and 4 (each within the scatter of the next, the first and the last beyond it).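

Among these compounds, replacing 2-(pyrrolidin-1-yl)ethyl with 1-ethylpiperidin-3-yl gives the first readable single-place step, a number 10.2 percentage points higher from compound 1 to compound 4 (beyond the scatter), in this assay. The number at this position therefore responds, modestly, to a change in the amine-bearing group on the saturated chain carbon. Nothing measured accounts for this step.

The compounds shown do not separate the contributions of the six-membered ring and the ethyl group. From the compounds shown here alone, how a morpholine ring or a dimethylamino group would read on this chain remains open.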